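The compounds below may be only part of what the source reports. "The series", "measured", "known", "first", "only" and "open" are said of these compounds alone.

Compound 1 `Cc1ccc2[nH]c(=O)c(CN(Cc3ccc(O)cc3)Cc3ccc(C(C)(C)C)cc3)cc2c1` carries two benzyl groups on its amine nitrogen, one of them bearing a hydroxy group. In a toxicity assay on MDCK cells (Canis lupus familiaris) for cytotoxicity, read by crystal violet staining, with a stated time of 48 h (a higher number here means that more compound is tolerated, a lower number that less compound is tolerated), compound 1 gives 4900 nM. Compound 2 `Cc1ccc2[nH]c(=O)c(CN(Cc3ccc(OCC(=O)OC(C)(C)C)cc3)Cc3ccc(C(C)(C)C)cc3)cc2c1` has (tert-butoxycarbonyl)methyl in place of hydrogen on an oxygen on an aromatic ring. In this assay compound 2 reaches only a limit of the assay, > 10000 nM. Compound 3 `Cc1ccc2[nH]c(=O)c(CN(Cc3ccc(C(N)=O)cc3)Cc3ccc(C(C)(C)C)cc3)cc2c1` has carbamoyl in place of hydroxy on an aromatic carbon. In this assay compound 3 likewise reaches only a limit, > 5000 nM. The steps are therefore floors: an at least 2.0-fold higher number from compound 1 to compound 2 (0.30 log units; that floor lies within the scatter), and an at least 1.0-fold higher number from compound 1 to compound 3 (0.00 log units; that floor lies within the scatter). The step that the two limits leave unreadable from compound 2 to compound 3 has both end points at limits. Compound 2 sits at the limit of > 10000 nM in this assay, at which 1 of the 3 values shown sits. Compound 3 sits at the limit of > 5000 nM in this assay, at which 1 of the 3 values shown sits. Among the compounds with values here, compound 3 thus stands among the compounds for which only a limit is known, while compound 1 alone yields a number, and none of the measured steps exceeds the scatter.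

Compound 4 `Cc1ccc2[nH]c(=O)c(CN(Cc3ccc(C(C)(C)C)cc3)[C@@H](C)c3ccc(F)cc3)cc2c1` differs from compound 3 by 1-(4-fluorophenyl)ethyl in place of 4-carbamoylbenzyl on an amine nitrogen. Within the data shown here, no measured step exchanges a whole benzylic group on the amine nitrogen; the measured steps only vary the substituent on one aromatic ring, and each stays within the scatter. One therefore expects no step beyond the scatter in this assay. Compound 4 is expected to give 8000 nM, between 3000 nM and 20000 nM. The expected step is a step that the limit leaves unreadable from compound 3 to compound 4, within the scatter.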

Compound 4, half-maximal cytotoxic concentration: > 5000 nM
Compound 4 gave a limit, no number (the forecaster's own chance of this, stated with the estimate: 60%); the middle value does not contradict the limit.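

In this assay, compound 4 shows that the whole group on the amine nitrogen can be exchanged and still yield only a limit of the assay, not a number: the limit of > 5000 nM in this assay, at which 2 of the 4 values shown sit. The earlier compounds shown here varied only the substituent on one aromatic ring, whereas here 4-carbamoylbenzyl gives way to 1-(4-fluorophenyl)ethyl, so the hydrogen-bond donor and acceptor leave and a defined stereocentre enters. The one readable new result is an at least 1.0-fold higher number from compound 1 to compound 4 (0.00 log units; that floor lies within the scatter), while the steps with limits at both ends, including the new one to compound 4 from compound 3, cannot be read.

Going by these compounds, compound 2, compound 3 and compound 4 have only limits, so whether they differ from one another at all remains open. Also open, on these data alone, is how the mirror-image form of 1-(4-fluorophenyl)ethyl, or an amine, a carboxylic acid or a longer chain on the group at this nitrogen, would read in this assay.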